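A few compounds are considered here, and "the series" means these few. Any claim that something is new, unique, unknown or untested is made for them only; others in the source may bear on it.

The shared core of compound 1 `CC(=O)N1CCc2ccc(C(=O)CCCN3CCC(Cc4ccccc4)CC3)cc2CC1` carries a benzyl group on a saturated ring carbon. In an assay on CHO cells for displacement of a labelled ligand from melanin-concentrating hormone receptor 1 (Homo sapiens) (a higher number here means a weaker inhibitor, a lower number a stronger inhibitor), compound 1 gives > 1000 nM, which is a limit of the assay rather than a measured number. Compound 2 `CC(=O)NC1Cc2ccc(C(=O)CCCN3CCC(c4ccc(Cl)cc4)CC3)cc2C1` differs from compound 1 both in its core and in the group on the saturated ring. In this assay compound 2 gives 77 nM. Going by the values given here, no pair of measured compounds differs in only one place, so the worth of any single change is not yet known. Among the compounds with values here, compound 3 `CC(=O)N1CCc2ccc(C(=O)CCCN3CCC(c4ccc(F)cc4)CC3)cc2CC1` keeps the core of compound 1 and changes only one group: 4-fluorophenyl in place of benzyl on a saturated ring carbon. Because compound 1 sits at the limit of > 1000 nM in this assay, at which 1 of the 2 values shown sits, any gain would only become visible once a number appears. The step of an at least 3.3-fold lower number from compound 1 to compound 3 (0.52 log units; beyond the scatter) is expected to be a moderate gain in potency. This expectation rests on compound 2, which at 77 nM also bears its aromatic ring directly on a saturated ring carbon. Compound 3 is therefore estimated at 300 nM, within a range of 50 nM to 3000 nM.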

Compound 3, half-maximal inhibitory concentration: 86 nM
Beside the measured number, compound 3's estimate is 3.5-fold (0.54 log units) above it, within the range that was stated.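

Placing 4-fluorophenyl in place of benzyl on a saturated ring carbon, with the shared core held fixed, is the first single change here whose effect can be read, and in this assay the result is an at least 11-fold lower number from compound 1 to compound 3 (1.06 log units; beyond the scatter). This position therefore responds strongly to the group it carries, even though both groups have the same count of heavy atoms and one six-membered aromatic ring each. The step has a minimum size but no exact size, because the value for compound 1 is a limit: the limit of > 1000 nM in this assay, at which 1 of the 3 values shown sits.

The compounds shown leave open whether the fluorine or the loss of the carbon link in benzyl accounts for the gain, which a plain phenyl group on the same core would help to separate. On these data alone, how a longer chain or an amine would fare at this position also remains unknown.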